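This account rests on a few compounds, and the source may have more. Where it says the series, first, only, none or still open, it means among the compounds named here.

Three compounds share one core and differ only in the group carried on the ring nitrogen of the six-membered non-aromatic ring. Compound 1 `NS(=O)(=O)N1CCC(C(=O)/C(=N/O)Nc2ccc(F)c(Br)c2)CC1` bears a sulfamoyl there and, in an assay for inhibition of Indoleamine 2,3-dioxygenase 1 (Homo sapiens), with a stated time of 1 h (on this read-out higher numbers stand for weaker inhibition and lower numbers for stronger inhibition), compound 1 gives 63 nM. Compound 2 `O=C(/C(=N/O)Nc1ccc(F)c(Br)c1)C1CCN(C(=O)Nc2ccccc2)CC1` carries a phenylcarbamoyl instead, and in this assay compound 2 gives 40 nM; the step of a 1.6-fold lower number from compound 1 to compound 2 (0.20 log units; within the scatter). Compound 3 `O=C(/C(=N/O)Nc1ccc(F)c(Br)c1)C1CCN(c2ccccc2)CC1` attaches a plain phenyl directly to that nitrogen, and in this assay compound 3 gives 149 nM, the highest of the three numbers, and so the weakest inhibition observed. Measured steps toward it point one way: a 2.4-fold higher number from compound 1 to compound 3 (0.37 log units; beyond the scatter) and a 3.7-fold higher number from compound 2 to compound 3 (0.57 log units; beyond the scatter), both beyond the scatter.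

Compound 4 `O=C(/C(=N/O)Nc1ccc(F)c(Br)c1)C1CCN(C(=O)c2ccccc2)CC1` takes the next step from compound 3: benzoyl in place of phenyl on an amine nitrogen in a ring. This puts a carbonyl back between the ring nitrogen and the aromatic ring, as compounds 1 and 2 both carry a group attached through a non-carbon-only link. Since removing such a link cost potency in the steps from compound 2 and compound 1 to compound 3, restoring one is expected to lower the number in this assay by a modest amount, roughly reversing those steps. The step from compound 3 to compound 4 is therefore estimated as a 2.7-fold lower number from compound 3 to compound 4 (0.43 log units; beyond the scatter). For compound 4, the expected value in this assay is 55 nM, with a range from 25 nM to 120 nM.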

Compound 4, half-maximal inhibitory concentration: 106 nM
Compound 4: middle estimate off by 1.9-fold (0.28 log units), on the low side, and the stated range covers the measured number.
By their numbers in this assay, from the lowest: compounds 2, 1, 4 and 3 (each within the scatter of the next, the first and the last beyond it).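

Putting a carbonyl between the ring nitrogen and the phenyl ring does not, on its own, give a clear change at this position: in this assay the swap to benzoyl gives a 1.4-fold lower number from compound 3 to compound 4 (0.15 log units; within the scatter) and so cannot be told apart from repeat-measurement noise. Going by these compounds alone, the group on that carbonyl carbon does count, since the single change at that place gives a 2.7-fold higher number from compound 2 to compound 4 (0.42 log units; beyond the scatter) in the same read-out, while the move from the sulfamoyl group gives a 1.7-fold higher number from compound 1 to compound 4 (0.23 log units; within the scatter) and stays unresolved. No measurement offered here explains why the anilino and phenyl groups on the carbonyl carbon differ.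

The compounds shown leave open whether the nitrogen of the anilino group or its phenyl ring matters more, which a methylamino group or a phenoxy group on the same carbonyl carbon would help to separate. On these data alone, it also remains open whether a benzyl group on the ring nitrogen, with a carbon link in place of the carbonyl, would fall with compound 3 or with compound 2.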